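Halogen and position change on the phenyl carbonyl arm

The source may hold more compounds than are shown below. What is called first, only, known or untested is meant among the compounds shown, and "the series" means these compounds.

Within the data shown here, compound 3 `Cc1ccc(OCC(=O)NNC(=O)c2cc3ccccc3oc2=O)c(C(=O)c2ccccc2Cl)c1` gives 54400 nM in a functional assay on DLA cells (Mus musculus) for cytotoxicity, read by LDH release, with a stated time of 48 h (on this read-out lower numbers stand for stronger inhibition and higher numbers for weaker inhibition), the highest of the three numbers so far. Compound 1 `COc1ccc(C(=O)c2cc(C)ccc2OCC(=O)NNC(=O)c2cc3ccccc3oc2=O)cc1` gives 43400 nM and compound 2 `Cc1ccc(OCC(=O)NNC(=O)c2cc3ccccc3oc2=O)c(C(=O)c2ccccc2Br)c1` gives 10600 nM; the step of a 5.1-fold higher number from compound 2 to compound 3 (0.71 log units; beyond the scatter) lies beyond the scatter, whereas a 1.3-fold higher number from compound 1 to compound 3 (0.10 log units; within the scatter) does not, so compound 3 and compound 1 cannot be told apart. Compound 4 `Cc1ccc(OCC(=O)NNC(=O)c2cc3ccccc3oc2=O)c(C(=O)c2ccc(Br)cc2)c1` differs from compound 3 by 4-bromophenyl in place of 2-chlorophenyl on a carbonyl carbon. Two kinds of measured step bear on this. The halogen exchange a 5.1-fold higher number from compound 2 to compound 3 (0.71 log units; beyond the scatter), read in reverse, shows bromo in place of chloro going with a lower number. The changes of the phenyl substituent, a 4.1-fold lower number from compound 1 to compound 2 (0.61 log units; beyond the scatter) and a 1.3-fold higher number from compound 1 to compound 3 (0.10 log units; within the scatter), show that which group stands on the carbonyl carbon can shift the number well beyond the scatter or not at all. Compound 4 carries both a halogen exchange and a changed substituent, so for compound 4 the expected step is a 2.7-fold lower number from compound 3 to compound 4 (0.43 log units; beyond the scatter), a lower number, with a wide range since 4-bromophenyl appears in no measured structure. The estimate for compound 4 is 20000 nM, between 7000 nM and 55000 nM.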

Compound 4, half-maximal inhibitory concentration: 95300 nM
For compound 4 the middle estimate is 4.8-fold (0.68 log units) below the measured one, and the stated range ends below it.
By their numbers in this assay, from the lowest: compound 2; then compounds 1, 3 and 4 (each within the scatter of the next, the first and the last beyond it).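

Moving the halogen on the carbonyl arm matters more than any other change seen so far: 4-bromophenyl in place of 2-bromophenyl gives a 9.0-fold higher number from compound 2 to compound 4 (0.95 log units; beyond the scatter), so bromo alone does not carry the low number of compound 2. The exchange of 2-chlorophenyl for 4-bromophenyl, a 1.8-fold higher number from compound 3 to compound 4 (0.24 log units; within the scatter), leaves compound 3 and compound 4 indistinguishable, and among the halogen-bearing arms only 2-bromophenyl stands apart. Against the 4-methoxyphenyl arm, bromo in place of methoxy gives a 2.2-fold higher number from compound 1 to compound 4 (0.34 log units; beyond the scatter), so on this arm the halogen goes with a higher number, in the opposite direction to the step from chloro to bromo in the 2-substituted pair.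

As far as these compounds go, whether the low number of compound 2 is particular to bromo stays open, as does how an aminophenyl or a carboxyphenyl group on the same carbonyl carbon would read. No measurement at hand accounts for any of these steps.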